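Chloro on the benzyl arm of the phenylglycine ester

A few compounds are considered here, and "the series" means these few. Any claim that something is new, unique, unknown or untested is made for them only; others in the source may bear on it.

compound 1 `CC(C)[C@H](N)C(=O)OCCCOC1(c2ccc(Cl)cc2)c2ccccc2C(=O)N1Cc1ccc(Cl)cc1`: 16000 nM
compound 2 `N[C@H](C(=O)OCCCOC1(c2ccc(Cl)cc2)c2ccccc2C(=O)N1Cc1ccccc1)c1ccccc1`: 14000 nM

In a functional assay on HCT-116 cells (Homo sapiens) for inhibition, read by fluorescence, with a stated time of 48 h (on this read-out higher numbers stand for weaker inhibition of growth and lower numbers for stronger inhibition of growth), compound 2 gives 14000 nM; this number and that of compound 1 lie within the scatter of each other, so the two esters stand level. Compound 3 `N[C@H](C(=O)OCCCOC1(c2ccc(Cl)cc2)c2ccccc2C(=O)N1Cc1ccc(Cl)cc1)c1ccccc1` is not yet measured. It differs from compound 2 by chloro in place of hydrogen on an aromatic carbon, in words chloro in place of hydrogen on an aromatic carbon. Among the compounds with values here, no measured pair isolates this change, and compound 1 carries it on a different ester, so no direction can be read from the numbers. The expected step in this assay is no change at the digits printed from compound 2 to compound 3 (within the scatter), none beyond the scatter. Compound 3 is estimated at 14000 nM, between 6000 nM and 35000 nM.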

Compound 3, concentration for 50% growth inhibition: 12000 nM
The estimate for compound 3 lay 1.2-fold (0.07 log units) above the measured number; low and high end bracket the measured number.
By their numbers in this assay, from the lowest: compounds 3, 2 and 1 (each within the scatter of the next).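

In this assay the change from benzyl to 4-chlorobenzyl now has a matched pair on the phenylglycine ester; it reads a 1.2-fold lower number from compound 2 to compound 3 (0.07 log units; within the scatter) and leaves the two compounds level. With the 4-chlorobenzyl arm held constant, phenyl in place of isopropyl reads a 1.3-fold lower number from compound 1 to compound 3 (0.12 log units; within the scatter) and likewise leaves the two esters level. Nothing available on these compounds gives a reason for either result. From the compounds shown here alone, whether fluoro or methoxy in place of chloro on the benzyl arm, or a carboxylic acid in place of the amino ester, would move the number beyond the scatter stays open.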